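This account rests on a few compounds, and the source may have more. Where it says the series, first, only, none or still open, it means among the compounds named here.

Measured so far:
compound 1, `N#CC1=C(N)OC(c2c[nH]c3ccccc23)=C(C#N)C1c1ccc(Br)cc1`: 22.7%
compound 2, `COc1ccc(C2C(C#N)=C(N)OC(c3c[nH]c4ccccc34)=C2C#N)cc1OC`: 28.1%

In a functional assay, tested at 400 ug/mL (on this read-out higher numbers stand for a stronger effect at the one concentration tested and lower numbers for a weaker effect), compound 1 gives 22.7%, the lower of the two numbers recorded so far. Compound 2 gives 28.1%; the step of a number 5.4 percentage points higher from compound 1 to compound 2 (within the scatter) stays within the scatter of repeated measurements, so the two values cannot be told apart with any confidence.

Compound 3, `CN(C)c1ccc(C2C(C#N)=C(N)OC(c3c[nH]c4ccccc34)=C2C#N)cc1`, is the next to be measured. It differs from compound 1 in a single place: dimethylamino in place of bromo on an aromatic carbon. Among the measured compounds shown here, only one measured step speaks to an exchange at this part of the molecule, namely a number 5.4 percentage points higher from compound 1 to compound 2 (within the scatter), which swapped a 3,4-dimethoxyphenyl for a 4-bromophenyl on a saturated ring carbon and left the read-out within the scatter. That is a thin basis, but it is the only one available.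

Given that a number 5.4 percentage points higher from compound 1 to compound 2 (within the scatter) stayed within the scatter, compound 3 is expected to show no step beyond the scatter in this assay; the estimated step is a number 2.3 percentage points higher from compound 1 to compound 3 (within the scatter). Compound 3 is therefore estimated at 25%, with a likely range from 14% to 36%.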

Compound 3, a percentage reported as activity, at one concentration (the size of the read-out at that concentration, not a potency): 26.7%
Compound 3: the middle estimate sits 1.7 percentage points below what was measured; low and high end bracket the measured number.
By their numbers in this assay, from the lowest: compounds 1, 3 and 2 (each within the scatter of the next).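

In this assay, the exchange of bromo for dimethylamino on an aromatic carbon, para to a large group, gives a number 4 percentage points higher from compound 1 to compound 3 (within the scatter). Among the compounds shown here, this is the first step that changes only this one substituent, and replacing a single bromine atom with a group of three heavy atoms, including a hydrogen-bond acceptor, leaves the read-out within the scatter. The step to the 4-(dimethylamino)phenyl group from the 3,4-dimethoxyphenyl group, a number 1.4 percentage points lower from compound 2 to compound 3 (within the scatter), also stays within the scatter, so the three phenyl groups on the saturated ring carbon cannot be told apart here, and no data shown offer an explanation for that.

Going by these compounds, it remains open whether this flat picture would hold for a carboxylic acid or a longer chain at the same aromatic carbon, since all three compounds carry only a bromo, a dimethylamino or two methoxy groups on that ring. Also open, on these data alone, is what changes to the shared core would do, and each number here comes from a single concentration, so none of them describes potency.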